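A few compounds are considered here, and "the series" means these few. Any claim that something is new, unique, unknown or untested is made for them only; others in the source may bear on it.

The three measured compounds share one core and differ only in the aryl group carried on an aromatic nitrogen. Compound 1 `CCOc1ccc(-n2nncc2CN2C(=O)C3(C(C#N)=C(N)Oc4c3c3nc5ccccc5nc3c3ccccc43)c3ccccc32)cc1` bears a 4-ethoxyphenyl there; in an ADME assay on L02 cells (Homo sapiens) for antiproliferative activity, read by MTT assay, with a stated time of 48 h (on this read-out higher numbers stand for weaker inhibition and lower numbers for stronger inhibition), compound 1 gives > 50000 nM, which is a limit of the assay and not a number. Compound 2 `Cc1ccc(-n2nncc2CN2C(=O)C3(C(C#N)=C(N)Oc4c3c3nc5ccccc5nc3c3ccccc43)c3ccccc32)cc1C` bears a 3,4-dimethylphenyl; in this assay compound 2 gives > 50000 nM, again a limit. Compound 3 `N#CC1=C(N)Oc2c(c3nc4ccccc4nc3c3ccccc23)C12C(=O)N(Cc1cnnn1-c1cc(Cl)ccc1Cl)c1ccccc12` bears a 2,5-dichlorophenyl; in this assay compound 3 gives > 50000 nM, also a limit. Compound 3 therefore stands where every measured value stands, namely at the limit of > 50000 nM in this assay, at which 3 of the 3 values shown sit. The steps between the measured compounds, a step that the two limits leave unreadable from compound 1 to compound 2, a step that the two limits leave unreadable from compound 1 to compound 3 and a step that the two limits leave unreadable from compound 2 to compound 3, each run between two limits and stay unreadable.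

The new compound 4 `N#CC1=C(N)Oc2c(c3nc4ccccc4nc3c3ccccc23)C12C(=O)N(Cc1cnnn1-c1ccc(Cl)c(Cl)c1)c1ccccc12` differs from compound 3 by 3,4-dichlorophenyl in place of 2,5-dichlorophenyl on an aromatic nitrogen. Within the data shown here, no measured step bears on this change in a readable way: all three steps exchange the aryl group on that nitrogen and none yields a size. The expectation in this assay is therefore that compound 4 will most probably return a limit once more, with the step that the limit leaves unreadable from compound 3 to compound 4 expected to be nothing that can be read. Compound 4 is estimated at 70000 nM, with a range from 30000 nM to 150000 nM.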

Compound 4, half-maximal inhibitory concentration: > 50000 nM
Compound 4 ended at the assay's limit; the forecaster's own chance of this, stated with the estimate: 80%; the middle value does not contradict the limit.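

No new step can be read: compound 4 gives a limit of the assay and not a number, as do compound 1, compound 2 and compound 3, so the steps from each of them to compound 4 stay unreadable: the limit of > 50000 nM in this assay, at which 4 of the 4 values shown sit.

The compounds shown leave open how far any of these aryl groups on the aromatic nitrogen would differ from another in this assay once a value inside the assay's range is available.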